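The source may hold more compounds than are shown below. What is called first, only, known or untested is meant among the compounds shown, and "the series" means these compounds.

Compound 1, `CC1=C(C(=O)Nc2ccc([N+](=O)[O-])cc2)C(c2ccc(Br)cc2)N=C(SCc2ccccc2)N1`, in a functional assay on the whole organism (artery, strain albino) with Rattus norvegicus as the target, with a stated time of 60 min, at a dose of 10 mg/kg by the oral route (a higher number here means more inhibition at the dose given (going by the name of the read-out), a lower number less inhibition), gives 8.2%.
Compound 2, `CC1=C(C(=O)Nc2ccc([N+](=O)[O-])cc2)C(c2ccc(Br)cc2)N=C(SCc2ccc(F)cc2)N1`, in this assay gives 9.7%.

Compound 1 shows the smaller of the two numbers, but the gap, a number 1.5 percentage points higher from compound 1 to compound 2 (within the scatter), is within the scatter, so the two are not distinguishable. Compound 3, `CC1=C(C(=O)Nc2ccc([N+](=O)[O-])cc2)C(c2cccc([N+](=O)[O-])c2)N=C(SCc2ccccc2)N1`, differs from compound 1 by 3-nitrophenyl in place of 4-bromophenyl on a saturated ring carbon. Within the data shown here, the only measured step alters the benzylsulfanyl group, not the saturated ring carbon, and was itself within the scatter, so no measured step bears on this change. No shift beyond the scatter is therefore expected. Compound 3 is estimated at 9%, between 0% and 22%, an expected step of a number 0.8 percentage points higher from compound 1 to compound 3 (within the scatter).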

Compound 3, a percentage reported as inhibition, in the whole organism at one dose (the size of the read-out at that dose, not a potency): 7.7%
Beside the measured number, compound 3's estimate is 1.3 percentage points above it, within the range that was stated.
By their numbers in this assay, from the lowest: compounds 3, 1 and 2 (each within the scatter of the next).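

Swapping 4-bromophenyl for 3-nitrophenyl on the saturated ring carbon gives a number 0.5 percentage points lower from compound 1 to compound 3 (within the scatter) in this assay. Among these compounds, this is the first measured change at this position, and it alters both the group on the phenyl ring and where that group sits, yet the two compounds cannot be told apart. Nothing measured here explains this result.

From the compounds shown here alone, only substituted phenyl groups appear at this carbon, so it remains open whether a very different group, such as a carboxylic acid or an amine, would shift the number beyond the scatter.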